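Compound 2 to compound 4: replacing piperidin-1-yl

This account rests on a few compounds, and the source may have more. Where it says the series, first, only, none or still open, it means among the compounds named here.

In a functional assay on KBVIN cells (Homo sapiens) for antiproliferative activity, read by sulforhodamine B assay, with a stated time of 3 days (a lower number here means a stronger inhibitor of growth, a higher number a weaker inhibitor of growth), compound 2 `O=C(c1cccc(Nc2ncc(F)c(Nc3ccc(F)cc3)n2)c1)N1CCCCC1` gives 13800 nM, the highest of the two numbers, while compound 1 `COc1ccc(N2CCN(C)CC2)cc1Nc1ncc(F)c(Nc2ccc(F)cc2)n1` gives 910 nM, a gap beyond the scatter. Compound 3 `CN(C)c1ccc(C(=O)Nc2cccc(Nc3ncc(F)c(Nc4ccc(F)cc4)n3)c2)cc1` reads > 10000 nM, which is a limit of the assay and not a number. Compound 4 `Cn1ccnc1NC(=O)c1cccc(Nc2ncc(F)c(Nc3ccc(F)cc3)n2)c1` carries (1-methyl-1H-imidazol-2-yl)amino in place of piperidin-1-yl on a carbonyl carbon. Going by the values given here, no measured pair shows this change alone, so the expectation starts from compound 2 at 13800 nM. In this assay the estimated step of a 1.5-fold lower number from compound 2 to compound 4 (0.19 log units; within the scatter) is expected to stay within the scatter, with no firm direction. Compound 4 is estimated at 9000 nM, with an expected range of 3000 nM to 25000 nM.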

Compound 4, concentration for 50% growth inhibition: 13100 nM
Estimate against measurement, compound 4: 1.5-fold (0.16 log units) below, and the stated range covers the measured number.
By their numbers in this assay, from the lowest: compound 1; then compounds 4 and 2 (each within the scatter of the next).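

Going by these compounds alone, exchanging piperidin-1-yl for (1-methyl-1H-imidazol-2-yl)amino on the carbonyl carbon gives the first single-place comparison, and in this assay the step reads a 1.1-fold lower number from compound 2 to compound 4 (0.02 log units; within the scatter). Adding a five-membered aromatic ring and a hydrogen-bond donor at this position therefore gives no separation between the two compounds. Both numbers lie in the same region as the assay limit: the limit of > 10000 nM in this assay, at which 1 of the 4 values shown sits.

Open, going by these compounds, is whether a small amine such as dimethylamino, or morpholin-4-yl, on this carbonyl carbon would separate from compound 2. Also open, on these data alone, is whether a carboxylic acid there would do so.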